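The source may report more compounds than this note shows. Statements on the series, on what has been measured and on what is new or still open speak of the compounds shown alone.

Measured compounds and values in a functional assay on HCT-116 cells (Homo sapiens) for inhibition, read by sulforhodamine B assay, with a stated time of 48 h; a higher number here means a weaker inhibitor, a lower number a stronger inhibitor:
Compound 1 `COc1cc(OC)cc(N2NC3=CC[C@@H](OC)O[C@@]3(c3ccccc3)CC2=O)c1` gives 18100 nM.
Compound 2 `COc1cc(OC)cc(N2NC3=CC[C@@H](OC)O[C@@]3(C)CC2=O)c1` gives 24300 nM.
Compound 3 `CO[C@@H]1CC=C2NN(c3cncnc3)C(=O)C[C@]2(C)O1` gives 15100 nM.

Compound 1 and compound 2 share a core and differ by phenyl in place of methyl on a saturated ring carbon. That change made a step of a 1.3-fold lower number from compound 2 to compound 1 (0.13 log units; within the scatter). Compound 3 has a different core from compound 2; how the two cores differ is not broken down here, and their two values in this assay lie within the scatter of each other, as do the values of compound 3 and compound 1.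

Compound 4 `CO[C@@H]1CC=C2NN(c3cncnc3)C(=O)C[C@]2(c2ccccc2)O1` is not yet measured. It differs from compound 3 by phenyl in place of methyl on a saturated ring carbon. For the measured compounds named here, this is the same kind of change as the one from compound 2 to compound 1, but the place is not the same: in compound 4 the phenyl sits on a six-membered non-aromatic ring with 1 oxygen, next to the ring oxygen and next to the ring atom that bears a fused ring, whereas in compound 1 it sits on a six-membered non-aromatic ring with 2 nitrogen. Because the earlier step of a 1.3-fold lower number from compound 2 to compound 1 (0.13 log units; within the scatter) was within the scatter, a step of about a 1.3-fold lower number from compound 3 to compound 4 (0.10 log units; within the scatter) is expected here. Compound 4 is therefore estimated at 12000 nM, with a range from 5000 nM to 30000 nM.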

Compound 4, half-maximal inhibitory concentration: 9130 nM
Beside the measured number, compound 4's estimate is 1.3-fold (0.12 log units) above it, within the range that was stated.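

In this assay, phenyl in place of methyl on a saturated ring carbon gave a 1.7-fold lower number from compound 3 to compound 4 (0.22 log units; within the scatter), and the step agrees with the one seen earlier on the other core: the same change on two cores in this assay, a 1.3-fold lower number (0.13 log units; within the scatter) from compound 2 to compound 1 and a 1.7-fold lower number (0.22 log units; within the scatter) from compound 3 to compound 4, 1.2-fold (0.09 log units) apart, within the scatter of two such steps. In this series the change therefore carries from one core to the other without a detectable difference between the two steps. Each step lies within the scatter on its own, however, so the pair does not show that the change affects the number on either core, and two cores say nothing about any other core.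

The compounds shown leave open whether any group at this saturated ring carbon would move the number beyond the scatter, as only methyl and phenyl stand there and an amine, a carboxylic acid or a longer chain in that place remains untested in what is shown. Every compound shown also carries the methoxy group, so what a hydroxyl group in its place would do is open too.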